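A new aryl group on the nitrogen of a shared core

The source may report more compounds than this note shows. Statements on the series, on what has been measured and on what is new or still open speak of the compounds shown alone.

Compound 1 `FC(F)(F)c1ccc(CSc2nc(Nc3ccccc3C(F)(F)F)c3ccccc3n2)cc1` and compound 2 `Cc1ccccc1Nc1nc(SCc2ccc(C(F)(F)F)cc2)nc2ccccc12` share a core and differ only in the aryl group on a nitrogen on an aromatic ring. In a functional assay on MGC-803 cells (Homo sapiens) for cytotoxicity, read by MTT assay, with a stated time of 72 h (on this read-out lower numbers stand for stronger inhibition and higher numbers for weaker inhibition), compound 1 gives > 50000 nM, which is a limit of the assay rather than a number. In this assay, within the data shown here, compound 2 gives 24400 nM, the only number recorded in this set. The step of an at least 2.0-fold lower number from compound 1 to compound 2 (0.31 log units; beyond the scatter) is known only against the limit (the limit of > 50000 nM in this assay, at which 1 of the 2 values shown sits), so its true size is at least what is stated. Compound 3 `O=[N+]([O-])c1cccc(Nc2nc(SCc3ccc(C(F)(F)F)cc3)nc3ccccc23)c1` has not been measured; it differs from compound 2 by 3-nitrophenyl in place of 2-methylphenyl on a nitrogen on an aromatic ring. Among the measured compounds shown here, no measured step involves a nitro group, and the single known step from compound 1 to compound 2 shows only that changing this aryl group can shift the number. Compound 3 is therefore expected to sit at 22000 nM, with a range from 6000 nM to 60000 nM. That estimate means an expected step of a 1.1-fold lower number from compound 2 to compound 3 (0.04 log units; within the scatter), which is not beyond the scatter.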

Compound 3, half-maximal inhibitory concentration: > 50000 nM
Compound 3 gave a limit, no number; the forecaster's own chance of this, stated with the estimate: 35%; middle value at least 2.2-fold (0.35 log units) from the limit.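

At this nitrogen, 3-nitrophenyl in place of 2-methylphenyl gives an at least 2.0-fold higher number from compound 2 to compound 3 (0.31 log units; beyond the scatter) in this assay, which adds a second aryl change to the one already seen. Of the three aryl groups now tested at this position, only 2-methylphenyl gives a number, while the step between the other two cannot be read. The true size of the new step is also unknown, since it too is measured against a limit: the limit of > 50000 nM in this assay, at which 2 of the 3 values shown sit.

This change replaces the group on the aryl ring and also moves it, so the compounds shown cannot separate the effect of the nitro group from that of its place on the ring. They also leave open how the number would respond to an amine or a carboxylic acid on this aryl ring.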